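The source may hold more compounds than are shown below. What is called first, only, known or untested is meant among the compounds shown, and "the series" means these compounds.

Measured compounds:

- compound 1, `O=c1cc(O)c2cc(F)ccc2o1`: 70700 nM
- compound 2, `O=c1cc(O)c2cc(Cl)ccc2o1`: 70700 nM
- compound 3, `O=c1oc2ccccc2c2nc3c(ccc4cc[nH]c43)c(-c3ccc(Cl)cc3)c12`: 70700 nM

In a functional assay on B16-F10 cells (Mus musculus) for cytotoxicity (on this read-out higher numbers stand for weaker inhibition and lower numbers for stronger inhibition), compound 2 gives 70700 nM and compound 1 gives 70700 nM. Within the data shown here, the two share a core and differ by fluoro in place of chloro on an aromatic carbon; the step of no change at the digits printed from compound 2 to compound 1 (within the scatter) is the only measured instance of this change. Compound 3 has a different core; the difference between the two cores is not broken down here. In this assay compound 3 gives 70700 nM, level with compounds 1 and 2 at the digits shown.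

Compound 4, `O=c1oc2ccccc2c2nc3c(ccc4cc[nH]c43)c(-c3ccc(F)cc3)c12`, has not been measured. It differs from compound 3 by fluoro in place of chloro on an aromatic carbon, the same kind of change as from compound 2 to compound 1, though the surroundings of the place differ: in compound 1 the aromatic carbon belongs to a six-membered aromatic ring of carbon only that is part of a fused or bridged system of two rings, meta to a fused ring and para to a fused ring, whereas in compound 4 it belongs to a six-membered aromatic ring of carbon only, para to a large group.

The expectation for the step of no change at the digits printed from compound 3 to compound 4 (within the scatter) is set beside the measured step of no change at the digits printed from compound 2 to compound 1 (within the scatter), which lies within the scatter; there is no second instance to weigh against it. Because compound 3 gives 70700 nM, compound 4 is expected to give about 70700 nM, with a range from 35000 nM to 141000 nM.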

Compound 4, half-maximal inhibitory concentration: 70700 nM
Compound 4: middle estimate and measured number agree at the digits printed; the measured number falls inside the stated range.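

Going from 4-chlorophenyl to 4-fluorophenyl in this assay gives no change at the digits printed from compound 3 to compound 4 (within the scatter), and set beside the same change on the core of compound 1, the step carries over: the same change on two cores in this assay, no change at the digits printed (within the scatter) from compound 2 to compound 1 and no change at the digits printed (within the scatter) from compound 3 to compound 4, 1.0-fold (0.00 log units) apart, within the scatter of two such steps. In these two pairs, fluoro in place of chloro on an aromatic carbon leaves the read-out where it was, in two different surroundings and on two different cores. This does not show that the change is silent on other cores or in other assays: there are only two pairs, and with compound 4 at 70700 nM all the compounds shown stand level, so neither pair shows how the change would read on a compound with a different value in this assay.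

The compounds shown leave open whether any group other than the two halogens on this aromatic carbon, such as a methoxy group, an amine, a carboxylic acid or a trifluoromethyl group, would separate from chloro and fluoro in this series. Also open, as far as these compounds go, is whether a change elsewhere on the core of compound 3, such as an alkyl chain on the ring nitrogen, would shift the value at all.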